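This account rests on a few compounds, and the source may have more. Where it says the series, first, only, none or still open, it means among the compounds named here.

Measured values in a functional assay on a cell-free system (plasma, Oryctolagus cuniculus) for inhibition, with stated times of 5 min, 1 min and 6 min; a higher number here means a weaker inhibitor, a lower number a stronger inhibitor:
- compound 1 `CCOC(=O)c1c(C)nc(-c2cccc(C#N)c2)n1OCc1ccccc1`: 5930 nM
- compound 2 `CCOC(=O)c1c(C)nc(-c2cccc(C#N)c2)n1OCc1ccccc1F`: 8990 nM
- compound 3 `CCOC(=O)c1c(C)nc(-c2cccc(C#N)c2)n1OCc1ccc(Cl)cc1`: 6830 nM

Compound 3 has no clear rank, as its value sits within the scatter of the other two. Compound 4 `CCOC(=O)c1c(C)nc(-c2cccc(C#N)c2)n1OCc1cccc(C#N)c1` has 3-cyanophenyl in place of 4-chlorophenyl on a saturated chain carbon bound to an oxygen on an aromatic ring.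

Three measured steps change this same aryl group, and all are small: a 1.5-fold higher number from compound 1 to compound 2 (0.18 log units; within the scatter), a 1.2-fold higher number from compound 1 to compound 3 (0.06 log units; within the scatter) and a 1.3-fold lower number from compound 2 to compound 3 (0.12 log units; within the scatter). None of these compounds carries a nitrile on that group, so the evidence is indirect. In this assay, no step beyond the scatter is therefore expected. The expected step is a 1.1-fold lower number from compound 3 to compound 4 (0.02 log units; within the scatter). The estimated value for compound 4 is 6500 nM, with an expected range from 3000 nM to 13000 nM.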

Compound 4, half-maximal inhibitory concentration: > 30000 nM
Compound 4: a limit, no number (the forecaster's own chance of this, stated with the estimate: 5%); at least 4.6-fold (0.66 log units) between middle value and limit.
By their numbers in this assay, from the lowest: compounds 1, 3 and 2 (each within the scatter of the next). At a limit, above all of these: compound 4.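

In this assay, fluoro and chloro on the aryl group at this saturated chain carbon gave no step beyond the scatter, but a nitrile does: an at least 5.0-fold higher number from compound 1 to compound 4 (0.70 log units; beyond the scatter), an at least 4.3-fold higher number from compound 3 to compound 4 (0.64 log units; beyond the scatter) and an at least 3.3-fold higher number from compound 2 to compound 4 (0.52 log units; beyond the scatter). So this group is not indifferent to every change, and among the four compounds shown only compound 4 stands apart. Compound 4 gives a limit and not a number, so these steps have no upper size: the limit of > 30000 nM in this assay, at which 1 of the 4 values shown sits.

As far as these compounds go, it stays open whether the nitrile itself or the 3-substituted pattern matters. A 3-chlorophenyl or a 4-cyanophenyl group in the same place would separate the two.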